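A few compounds are considered here, and "the series" means these few. Any claim that something is new, unique, unknown or untested is made for them only; others in the source may bear on it.

Values in a functional assay on HeLa cells (Homo sapiens) for inhibition, read by MTT assay, with a stated time of 48 h; a higher number here means a weaker inhibitor, a lower number a stronger inhibitor:
- compound 1 `CCOC(=O)C1=C(NN=C(C(C)=O)C(C)=O)Nc2[nH]nc(C)c2C1c1ccc(N(C)C)cc1`: 17000 nM
- compound 2 `CCOC(=O)C1=C(N/C=N/c2nnc(S(N)(=O)=O)s2)Nc2[nH]nc(C)c2C1c1ccc(N(C)C)cc1`: 26300 nM
- compound 3 `CCOC(=O)C(=NNC1=C(C(=O)OCC)C(c2ccc(N(C)C)cc2)c2c(C)n[nH]c2N1)C(=O)OCC`: 83800 nM

Compound 3 has the highest number of the three and is the weakest inhibitor in this assay. The nearest comparison is a 3.2-fold higher number from compound 2 to compound 3 (0.50 log units; beyond the scatter), and the furthest is a 4.9-fold higher number from compound 1 to compound 3 (0.69 log units; beyond the scatter).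

The next compound is compound 4 `CCOC(=O)C1=C(N/N=C(/C(C)=O)C(=O)OCC)Nc2[nH]nc(C)c2C1c1ccc(N(C)C)cc1`, which differs from compound 3 at the amine nitrogen: a group of 10 heavy atoms (6 carbon, 1 nitrogen, 3 oxygen; no ring) in place of a group of 12 heavy atoms (7 carbon, 1 nitrogen, 4 oxygen; no ring), on an amine nitrogen.

The entering group is smaller than the group of compound 3 and larger than the group of compound 1 by heavy-atom count. The step of a 4.9-fold higher number from compound 1 to compound 3 (0.69 log units; beyond the scatter) therefore bears most directly on this change. The step of a 3.2-fold higher number from compound 2 to compound 3 (0.50 log units; beyond the scatter) bears less directly, since compound 2 carries a ring in that group, and a 1.5-fold higher number from compound 1 to compound 2 (0.19 log units; within the scatter) says little for the same reason. Part of the larger step is expected to be reversed, giving a modest move to a lower number. The expected change is a 2.2-fold lower number from compound 3 to compound 4 (0.34 log units; beyond the scatter). For compound 4 the estimated value is 38000 nM, with an expected range of 15000 nM to 85000 nM.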

Compound 4, half-maximal inhibitory concentration: > 100000 nM
Compound 4 gave a limit, no number (the forecaster's own chance of this, stated with the estimate: 5%); middle value at least 2.6-fold (0.42 log units) from the limit.
By their numbers in this assay, from the lowest: compounds 1 and 2 (each within the scatter of the next); then compound 3. At a limit, above all of these: compound 4.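

In this assay compound 4 gives no number, only a limit of the assay: the limit of > 100000 nM in this assay, at which 1 of the 4 values shown sits.
The change at the amine nitrogen can be read as a floor: an at least 5.8-fold higher number from compound 1 to compound 4 (0.76 log units; beyond the scatter) and an at least 3.8-fold higher number from compound 2 to compound 4 (0.58 log units; beyond the scatter) both stand beyond the scatter, while an at least 1.1-fold higher number from compound 3 to compound 4 (0.07 log units; that floor lies within the scatter) gives a floor that by itself does not separate the pair. Among the groups without a ring, heavy-atom count alone does not order the series, and compound 4 goes against such a pattern: its group of 10 heavy atoms sits in size between those of compound 1 and compound 3, yet its limit stands above the numbers of both.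

On these data alone, the true value of compound 4 remains open, so the size of its step from compound 3 cannot be fixed. Also open, as far as these compounds go, is whether the ethyl ester in the entering group matters, which a carboxylic acid or a primary amide in its place would test.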